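Butylsulfanyl for propoxy on a TRPV1 antagonist scaffold

The compounds below may be only part of what the source reports. "The series", "measured", "known", "first", "only" and "open" are said of these compounds alone.

Measured compounds:
compound 1, `CC(C(=O)NCc1ccc(C(F)(F)F)cc1N1CCC(C(F)(F)F)CC1)c1ccc(NS(C)(=O)=O)c(F)c1`, 0.4 nM
compound 2, `CCCOc1cc(C(F)(F)F)ccc1CNC(=O)C(C)c1ccc(NS(C)(=O)=O)c(F)c1`, 2 nM

Both compounds were tested in an assay on CHO cells for antagonist activity at transient receptor potential cation channel subfamily V member 1 (Homo sapiens), read by FLIPR; on this read-out higher numbers stand for weaker inhibition and lower numbers for stronger inhibition. Compound 1 gives 0.4 nM, and compound 2 gives 2 nM. Within the data shown here, the single measured step, a 5.0-fold higher number from compound 1 to compound 2 (0.70 log units; beyond the scatter), puts compound 2 at the higher of the two numbers, so on this small set compound 2 is the weaker inhibitor of the pair.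

Compound 3, `CCCCSc1cc(C(F)(F)F)ccc1CNC(=O)C(C)c1ccc(NS(C)(=O)=O)c(F)c1`, has not yet been measured. It differs from compound 2 in one place: butylsulfanyl in place of propoxy on an aromatic carbon, the replacement sitting ortho to a large group and meta to a trifluoromethyl group on the six-membered aromatic ring of carbon only. Among the measured compounds shown here, no measured step bears directly on this exchange; the only known step concerns a different replacement at the same place and is of modest size. With no guidance on the swap of an oxygen-linked chain for a sulfur-linked one, a step of no more than modest size in this assay is expected, in either direction, and most likely within the scatter, giving an expected 1.5-fold higher number from compound 2 to compound 3 (0.18 log units; within the scatter).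

For compound 3 the estimate in this assay is therefore 3 nM, expected to fall between 0.8 nM and 12 nM.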

Compound 3, inhibition constant: 1.9 nM
For compound 3 the middle estimate is 1.6-fold (0.20 log units) above the measured one; low and high end bracket the measured number.
By their numbers in this assay, from the lowest: compound 1; then compounds 3 and 2 (each within the scatter of the next).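

In this assay, the exchange of propoxy for butylsulfanyl on this aromatic carbon gives a 1.1-fold lower number from compound 2 to compound 3 (0.02 log units; within the scatter), so at this position the sulfur-linked chain and the oxygen-linked chain stand level, which the earlier pair could not show. Measured against the 4-(trifluoromethyl)piperidin-1-yl group of compound 1, butylsulfanyl gives a 4.8-fold higher number from compound 1 to compound 3 (0.68 log units; beyond the scatter), and propoxy gives a 5.0-fold higher number from compound 1 to compound 2 (0.70 log units; beyond the scatter), so both open chains now lie beyond the scatter on the same side of compound 1, and the gap to that compound is no longer seen with a single chain only. Nothing in the data given accounts for any of these numbers.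

The exchange alters the linking atom and the chain together, so the compounds shown cannot separate the two, and the level result could reflect either a true match or two opposing contributions; butoxy or propylsulfanyl at this place would tell those apart. Also open, as far as these compounds go, is whether the low number of compound 1 belongs to cyclic amines in general, which a morpholine or an unsubstituted piperidine at this position would address.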